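Sulfonamide to Sulfone on a Shared Acetylene-Linked Core

The source may report more compounds than this note shows. Statements on the series, on what has been measured and on what is new or still open speak of the compounds shown alone.

Measured so far:
compound 1, `Cc1ccc(S(=O)(=O)N(C)C(C)C)cc1C#Cc1cc(Cl)ccc1OCC(=O)O`, 140 nM
compound 2, `CC(C)c1ccc(S(C)(=O)=O)cc1C#Cc1cc(Cl)ccc1OCC(=O)O`, 360 nM

Of the compounds shown here, two sharing one core have been measured in a functional assay on cells for antagonist activity at prostaglandin D2 receptor 2 (Homo sapiens), read by flow cytometry, with a stated time of 10 min; on this read-out lower numbers stand for stronger inhibition and higher numbers for weaker inhibition. Compound 1 gives 140 nM, and compound 2 gives 360 nM. Of the two numbers, that of compound 1 is the lower one, and the gap to compound 2 lies beyond the usual scatter of the read-out. Among the measured compounds shown here, compound 1 and compound 2 differ in more than one place, so the pair carries no single step that could be read on its own.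

Compound 3, `Cc1ccc(S(=O)(=O)CC(C)C)cc1C#Cc1cc(Cl)ccc1OCC(=O)O`, has not yet been measured. It differs from compound 1 in one place only: isobutyl in place of isopropyl(methyl)amino on a sulfonyl sulfur. For the measured compounds named here, no measured pair shows this particular change, so any expectation for compound 3 must rest on compound 1 alone. A modest step from compound 1 to compound 3 is expected, a 1.6-fold higher number from compound 1 to compound 3 (0.20 log units; within the scatter), likely in the direction of a somewhat higher number, though a step that stays within the scatter would not be surprising. Compound 3 is accordingly estimated at 220 nM in this assay, with a range from 70 nM to 700 nM.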

Compound 3, half-maximal inhibitory concentration: 120 nM
The estimate for compound 3 lay 1.8-fold (0.26 log units) above the measured number; the measured number falls inside the stated range.
By their numbers in this assay, from the lowest: compounds 3 and 1 (each within the scatter of the next); then compound 2.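

In this assay, putting isobutyl in place of isopropyl(methyl)amino on a sulfonyl sulfur gives a 1.2-fold lower number from compound 1 to compound 3 (0.07 log units; within the scatter) and so places neither compound ahead of the other. Among the compounds shown here, this is the first single change read at this position, as compound 1 and compound 2 differ in more than one place, and it shows that for this pair the isopropyl(methyl)sulfamoyl to isobutylsulfonyl exchange moves the number by no more than the usual scatter, even though the nitrogen is gone and the chain is of a different shape. Nothing measured here offers an explanation for this result.

What the compounds shown leave open is whether this holds for other groups on the sulfonyl sulfur, such as a longer chain, a phenyl ring or a piperidine, or only for the two groups seen so far. On these data alone, the separate contributions of the differences between compound 1 and compound 2 also stay open, and a compound carrying only one of those differences would be needed to read them apart.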